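A few compounds are considered here, and "the series" means these few. Any claim that something is new, unique, unknown or untested is made for them only; others in the source may bear on it.

Three compounds share one core and differ only in the group on an aromatic carbon of the pyrimidine ring. Compound 1 `COc1ncc(-c2nc(C(F)(F)F)sc2N2CCN(C(=O)Cn3nc(C)nc3C)[C@H](C)C2)cn1` carries a methoxy there, and in a functional assay on U2OS cells for antagonist activity at C-X-C chemokine receptor type 3 (Homo sapiens), read by beta-arrestin recruitment (on this read-out higher numbers stand for weaker inhibition and lower numbers for stronger inhibition), compound 1 gives 558 nM. Compound 2 `Cc1nc(C)n(CC(=O)N2CCN(c3sc(C(F)(F)F)nc3-c3cnc(OC(C)C)nc3)C[C@H]2C)n1` carries an isopropoxy, and in this assay compound 2 gives 138 nM. Compound 3 `CCc1ncc(-c2nc(C(F)(F)F)sc2N2CCN(C(=O)Cn3nc(C)nc3C)[C@H](C)C2)cn1` carries an ethyl, and in this assay compound 3 gives 1430 nM, the highest of the three numbers, so it is the weakest inhibitor of the set.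

Compound 4 `Cc1nc(C)n(CC(=O)N2CCN(c3sc(C(F)(F)F)nc3-c3cnc(C4CC4)nc3)C[C@H]2C)n1` is the next step: cyclopropyl in place of ethyl on an aromatic carbon. For the measured compounds named here, two measured steps bear on this change. The step of a 2.6-fold higher number from compound 1 to compound 3 (0.41 log units; beyond the scatter) and the step of a 10-fold higher number from compound 2 to compound 3 (1.02 log units; beyond the scatter) show that the ethyl was worse than either oxygen-linked group, and the step of a 4.0-fold lower number from compound 1 to compound 2 (0.61 log units; beyond the scatter) shows that the larger group at this position gave the lower number. Cyclopropyl is carbon-linked like ethyl but larger, so a modest move toward lower numbers in this assay is expected, a 2.0-fold lower number from compound 3 to compound 4 (0.31 log units; beyond the scatter). Compound 4 is therefore estimated at 700 nM in this assay, within a range of 250 nM to 2000 nM.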

Compound 4, half-maximal inhibitory concentration: 349 nM
Compound 4: the middle estimate sits 2.0-fold (0.30 log units) above what was measured; the measured number falls inside the stated range.
By their numbers in this assay, from the lowest: compound 2; then compounds 4 and 1 (each within the scatter of the next); then compound 3.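

In this assay, the change from ethyl to cyclopropyl at this position, between two ring nitrogen atoms, gives a 4.1-fold lower number from compound 3 to compound 4 (0.61 log units; beyond the scatter), so a group linked through carbon can also give a much lower number than ethyl does, and an oxygen link is not required for that. Cyclopropyl and methoxy cannot be told apart here, with a 1.6-fold lower number from compound 1 to compound 4 (0.20 log units; within the scatter), while the isopropoxy group still gives the lower number, as a 2.5-fold higher number from compound 2 to compound 4 (0.40 log units; beyond the scatter) shows. No measurement here explains why the ring changes the number.

The compounds shown do not separate the effect of the linking atom from that of group size, which an isopropyl group, the carbon-linked counterpart of isopropoxy, could help to test. From the compounds shown here alone, how an amine such as dimethylamino or a larger cyclobutyl ring would behave at this position also remains open.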